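The source may report more compounds than this note shows. Statements on the series, on what has been measured and on what is new or still open speak of the compounds shown alone.

Measured so far:
Compound 1, `O=C(CCn1c(C(F)(F)F)nc2ccccc21)N/N=C/c1c(O)ccc2ccccc12`, in a physicochemical assay for solubility, read by fluorescence and spectrophotometry (a lower number here means a less soluble compound, a higher number a more soluble compound), compound 1 gives 30000 nM.
Compound 2, `O=C(CCn1cnc2ccccc21)N/N=C/c1c(O)ccc2ccccc12`, in this assay compound 2 gives 30000 nM.
Compound 3, `Cc1nccn1CCC(=O)N/N=C/c1c(O)ccc2ccccc12`, in this assay compound 3 gives 10000 nM.

Compound 2 sits level with compound 1, and both stand above compound 3. The two known steps are no change at the digits printed from compound 1 to compound 2 (within the scatter) and a 3.0-fold lower number from compound 2 to compound 3 (0.48 log units; beyond the scatter).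

The new compound is compound 4, `CN(C)Cc1nc2ccccc2n1CCC(=O)N/N=C/c1c(O)ccc2ccccc12`. It differs from compound 2 by (dimethylamino)methyl in place of hydrogen on an aromatic carbon, the new group sitting on an aromatic carbon of a five-membered aromatic ring with two nitrogen atoms, part of a fused system of two rings, between two ring nitrogen atoms.

The step that bears most on this change is the one at the same carbon, no change at the digits printed from compound 1 to compound 2 (within the scatter), which shows that swapping a group there for hydrogen left the number unchanged. The step of a 3.0-fold lower number from compound 2 to compound 3 (0.48 log units; beyond the scatter), which replaced the whole fused ring, was only modest. A step beyond the scatter is therefore not expected in this assay. Compound 4 is expected to give about 30000 nM, with a range from 12000 nM to 80000 nM. This estimate means the expected step is no change at the digits printed from compound 2 to compound 4 (within the scatter).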

Compound 4, solubility: 90000 nM
For compound 4 the middle estimate is 3.0-fold (0.48 log units) below the measured one; the measured number lies above the stated range.
By their numbers in this assay, from the lowest: compound 3; then compounds 1 and 2 (each within the scatter of the next); then compound 4.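

At the aromatic carbon between two ring nitrogen atoms, this assay does respond to the group present: (dimethylamino)methyl in place of hydrogen gives a 3.0-fold higher number from compound 2 to compound 4 (0.48 log units; beyond the scatter) and the same group in place of trifluoromethyl gives a 3.0-fold higher number from compound 1 to compound 4 (0.48 log units; beyond the scatter). Hydrogen and trifluoromethyl had given the same printed number, so that earlier step alone did not show that a change at this carbon could shift the read-out, and here it moves the number upward. No measurement shown here explains the rise.

A single group cannot show whether the rise needs the amine nitrogen or would also come with a carbon-only chain such as ethyl. Going by these compounds, whether a cyclic amine such as morpholin-4-ylmethyl at this carbon would give a similar number also remains open.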